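Dropping the trifluoromethyl from the benzamide of compound 2

A few compounds are considered here, and "the series" means these few. Any claim that something is new, unique, unknown or untested is made for them only; others in the source may bear on it.

Compound 1 `O=C(Nc1cccc(-n2cc(-c3ccncc3)c(-c3ccc(Cl)c(O)c3)n2)c1)Nc1ccc(Cl)c(Cl)c1` and compound 2 `COc1cc(-c2nn(-c3cccc(NC(=O)c4cccc(C(F)(F)F)c4)c3)cc2-c2ccncc2)ccc1Cl` have both been run in a functional assay on NCI-H226 cells (Homo sapiens) for inhibition, read by sulforhodamine B assay, with a stated time of 48 h; on this read-out higher numbers stand for lower toxicity in this test and lower numbers for higher toxicity in this test. For compound 1 the reading is a limit of the test, > 32500 nM, as noted at the limit of > 32500 nM in this assay, at which 1 of the 2 values shown sits. For compound 2 the reading is likewise a limit, > 50000 nM, as noted at the limit of > 50000 nM in this assay, at which 1 of the 2 values shown sits. Going by the values given here, compound 2 therefore stands at a limit, as does the only other value shown, and no measured step between the two exists. Compound 3 `COc1cc(-c2nn(-c3cccc(NC(=O)c4ccccc4)c3)cc2-c2ccncc2)ccc1Cl` has not yet been measured. It differs from compound 2 in one place: hydrogen in place of trifluoromethyl on an aromatic carbon. Among the compounds with values here, with no measured step to lean on, a change of no more than the usual scatter is expected in this assay, estimated as a number no higher from compound 2 to compound 3 (the limit leaves the size open). Compound 3 is expected to give 50000 nM, within 20000 nM to 120000 nM, most likely reported again only as a limit.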

Compound 3, concentration lethal to 50% of the cells: > 100000 nM
Compound 3 gave a limit, no number (the forecaster's own chance of this, stated with the estimate: 75%); middle value at least 2.0-fold (0.30 log units) from the limit.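

In this assay compound 3 gives > 100000 nM, a limit and not a number. Compound 2 also stands at a limit, and the step between compound 2 and compound 3 cannot be read. The compounds shown leave open whether hydrogen in place of trifluoromethyl changes the reading at all.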